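Isopropyl to Isobutyl on a Five-Membered Aromatic Ring

The compounds below may be only part of what the source reports. "The series", "measured", "known", "first", "only" and "open" are said of these compounds alone.

Of the compounds shown here, three sharing one core have been measured in an assay on microsomes from liver for inhibition of acyl-CoA desaturase 1 (Rattus norvegicus); a higher number here means a weaker inhibitor, a lower number a stronger inhibitor. Compound 1 `CC(C)(C)c1nnc(-c2ccc(N3CCC(Oc4ccccc4C(F)(F)F)CC3)nn2)s1` gives 710 nM. Compound 2 `Brc1cccc(OC2CCN(c3ccc(-n4ccnc4)nn3)CC2)c1` gives 23 nM. Compound 3 `CC(C)c1nnc(-c2ccc(N3CCC(Oc4ccccc4C(F)(F)F)CC3)nn2)s1` gives 8.8 nM, the lowest number of the three; compound 2 sits somewhat above it, and compound 1 sits far above it. The one step that links two of these compounds directly, an 81-fold lower number from compound 1 to compound 3 (1.91 log units; beyond the scatter), came from hydrogen in place of methyl on a saturated chain carbon bound to an aromatic carbon and two saturated chain carbons.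

Compound 4 `CC(C)Cc1nnc(-c2ccc(N3CCC(Oc4ccccc4C(F)(F)F)CC3)nn2)s1` has not yet been measured. Its change from compound 3 is isobutyl in place of isopropyl on an aromatic carbon. Going by the values given here, no measured step shows this exact change. The step from compound 1 to compound 3 concerns the same group and shows that one extra carbon at the branching point changed the number greatly, whereas isobutyl moves the branching one bond further out instead of adding to it. The expectation is therefore a step of modest size in this assay, a 1.7-fold higher number from compound 3 to compound 4 (0.23 log units; within the scatter), most likely toward a slightly higher number. For compound 4 the estimate is 15 nM, with a range from 4 nM to 60 nM.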

Compound 4, half-maximal inhibitory concentration: 37 nM
Compound 4: middle estimate off by 2.5-fold (0.39 log units), on the low side, and the stated range covers the measured number.
By their numbers in this assay, from the lowest: compound 3; then compounds 2 and 4 (each within the scatter of the next); then compound 1.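

On this aromatic carbon of the five-membered ring, moving the branching one bond further out is not a neutral change in this assay: isobutyl in place of isopropyl gives a 4.2-fold higher number from compound 3 to compound 4 (0.62 log units; beyond the scatter) and so costs a modest but real amount. The same isobutyl group still does far better than tert-butyl, with a 19-fold lower number from compound 1 to compound 4 (1.28 log units; beyond the scatter) as the step between them. Across compound 1, compound 3 and compound 4, which differ only at this carbon, the number is lowest with isopropyl, higher with isobutyl and highest with tert-butyl, so both the size of the group and the place of its branch matter here.

Nothing available explains why these groups differ in this way. Still open, from the compounds shown here alone, is how a straight propyl chain, a smaller ethyl group or a cyclopropyl ring on this same carbon would compare with isopropyl.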